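Swapping chloro for methoxy beside a phenol

The source may hold more compounds than are shown below. What is called first, only, known or untested is meant among the compounds shown, and "the series" means these compounds.

Of the compounds shown here, three have been measured in an assay on tissue (RPTEC cells) for inhibition of solute carrier family 22 member 12 (Homo sapiens), read by scintillation counting, with stated times of 15 min and 2 h; a higher number here means a weaker inhibitor, a lower number a stronger inhibitor. Compound 2, `N#Cc1cc(C(=O)N2CCc3ccccc32)cc(Cl)c1O`, gives 14700 nM. Compound 1, `COc1cc(C(=O)N2CCc3ccccc32)cc(C#N)c1O`, reaches only the limit of the assay, > 100000 nM, so no number is known for it. Compound 3, `O=C(c1cc(Cl)c(O)c(C(F)(F)F)c1)N1CS(=O)(=O)c2ccccc21`, gives 2600 nM; the difference between its core and that of compound 2 is not broken down here.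

Going by the values given here, the one step that can be counted is methoxy in place of chloro on an aromatic carbon, and it produced an at least 6.8-fold higher number from compound 2 to compound 1 (0.83 log units; beyond the scatter). Because the limit of > 100000 nM in this assay, at which 1 of the 3 values shown sits, caps what compound 1 can show, the true step may be larger than stated.

The unmeasured compound 4, `COc1cc(C(=O)N2CS(=O)(=O)c3ccccc32)cc(C(F)(F)F)c1O`, is built from compound 3 by methoxy in place of chloro on an aromatic carbon. This is the same kind of change as from compound 2 to compound 1, though the surroundings differ: in compound 1 the new methoxy sits meta to a cyano group (2 heavy atoms), in compound 4 meta to a trifluoromethyl group (4 heavy atoms).

Resting on the step from compound 2 to compound 1, which showed an at least 6.8-fold higher number from compound 2 to compound 1 (0.83 log units; beyond the scatter), a clearly weaker inhibitor is expected, with an estimated step of a 12-fold higher number from compound 3 to compound 4 (1.06 log units; beyond the scatter). Compound 4 is therefore estimated at 30000 nM in this assay, between 8000 nM and 150000 nM, with a real chance that only a limit is reported.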

Compound 4, half-maximal inhibitory concentration: 17800 nM
Beside the measured number, compound 4's estimate is 1.7-fold (0.23 log units) above it; low and high end bracket the measured number.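

In this assay, methoxy in place of chloro on an aromatic carbon gave a 6.8-fold higher number from compound 3 to compound 4 (0.84 log units; beyond the scatter), so on the core of compound 3, as on the core of compound 2, the swap comes with weaker inhibition. Set side by side, the two cases point the same way, but they cannot be called equal in size: the same change on two cores in this assay, an at least 6.8-fold higher number (0.83 log units; beyond the scatter) from compound 2 to compound 1 and a 6.8-fold higher number (0.84 log units; beyond the scatter) from compound 3 to compound 4; the limit leaves it open whether they differ. What carries across these two cores is therefore the direction of the change, while its size is firmly known only for the second case, and two cores alone make no rule for the whole series.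

The compounds shown leave open whether anything else at that same place would do as well as chloro or better, for example a fluoro group, an amine or a longer chain such as ethoxy. They also leave open whether the swap would cost the same with a group other than nitrile or trifluoromethyl elsewhere on the ring, such as a carboxylic acid, and what happens when the hydroxy group itself is replaced.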